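Oral tail flick series: from compound 1 to compound 3

The source may report more compounds than this note shows. Statements on the series, on what has been measured and on what is new or still open speak of the compounds shown alone.

Measured so far:
Compound 1, `O=C(CN(c1ncnc2c1ncn2C1CCCCO1)C1CC1)NCC(=O)OCc1ccccc1`, 25.9%
Compound 2, `CSCC[C@H](NC(=O)CN(c1nc(Cl)nc2[nH]cnc12)C1CC1)C(=O)O`, 14%

In a functional assay on the whole organism (Tail, strain ICR) with Mus musculus as the target, in the tail flick test, with a stated time of 90 min, at a dose of 25 umol/kg by the oral route (a lower number here means a weaker effect, a higher number a stronger effect of the compound at the dose given), compound 1 gives 25.9%, the higher of the two numbers. In the same assay compound 2 gives 14%, and the gap between them lies beyond the usual scatter. The two compounds differ in several places at once, so the gap cannot be tied to any single change.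

Compound 3, `CC(C)C[C@H](NC(=O)CN(c1ncnc2c1ncn2C1CCCCO1)C1CC1)C(=O)OCc1ccccc1`, has not yet been measured in this assay. Against compound 1 it carries isobutyl in place of hydrogen on a saturated chain carbon bound to an amide-type nitrogen and a carbonyl carbon. Going by the values given here, no measured pair isolates this change, so its direction is not known from the data. The step of a number 4.1 percentage points higher from compound 1 to compound 3 (within the scatter) is expected to be small, within or just beyond the scatter. For compound 3 the expected value is 30%, with a range from 10% to 55%.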

Compound 3, a percentage reported as activity, at one dose (the size of the read-out at that dose, not a potency): 28.2%
Compound 3: middle estimate off by 1.8 percentage points, on the high side; measured number inside the range.
By their numbers in this assay, from the lowest: compound 2; then compounds 1 and 3 (each within the scatter of the next).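

Going by these compounds alone, the step of a number 2.3 percentage points higher from compound 1 to compound 3 (within the scatter) in this assay is the first reading that isolates a single change, isobutyl in place of hydrogen on a saturated chain carbon bound to an amide-type nitrogen and a carbonyl carbon. At this position, the added 4 heavy atoms leave the read-out within the scatter, so this carbon accepts isobutyl without a measurable loss or gain in this test. Nothing available bears on why the change leaves the read-out there.

Still open, as far as these compounds go, is whether an amine, a carboxylic acid or a longer chain on this same carbon would keep the read-out within the scatter of compound 1 or move it beyond. A single pair also cannot show whether isobutyl behaves the same way on a different core.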